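Working notes on compound 1 and its methoxyphenyl counterpart

This account rests on a few compounds, and the source may have more. Where it says the series, first, only, none or still open, it means among the compounds named here.

Measured so far:
compound 1, `Cc1ccccc1OCC(=O)Nc1ccc(OCC(=O)O)c(F)c1`: 20.8%
compound 2, `CC(C)(C)c1cccc(OCC(=O)Nc2ccc(OCC(=O)O)c(F)c2)c1`: 40.2%

Both compounds were read in a functional assay on CHO cells for agonist activity at Free fatty acid receptor 1 (Homo sapiens), read by FLIPR, tested at 100 nM; on this read-out higher numbers stand for a stronger effect at the one concentration tested and lower numbers for a weaker effect. Compound 1 stands lowest of the two numbers available; compound 2 is the only other entry, and it lies higher by an amount beyond the usual scatter. Among the compounds with values here, no pair of measured compounds differs in a single place, so nothing measured yet shows how a change at the one position in question moves the read-out.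

Compound 3, `COc1ccc(OCC(=O)Nc2ccc(OCC(=O)O)c(F)c2)cc1`, has not been measured. It differs from compound 1 in one place: 4-methoxyphenyl in place of 2-methylphenyl on an oxygen on a saturated carbon. Within the data shown here, no measured step bears directly on this change. Among the measured compounds shown here, the only guide is that compound 2, which also carries a different six-membered aromatic ring of carbon only on an oxygen on a saturated carbon, reads higher than compound 1. The step of a number 9.2 percentage points higher from compound 1 to compound 3 (within the scatter) is therefore expected to be modest and upward, and may well fall within the scatter. Compound 3 is expected to give 30%, with a range from 12% to 55%.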

Compound 3, a percentage reported as activity, at one concentration (the size of the read-out at that concentration, not a potency): 5.73%
For compound 3 the middle estimate is 24.3 percentage points above the measured one; measured number below the stated range.
By their numbers in this assay, from the lowest: compound 3; then compound 1; then compound 2.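

Within the data shown here, on an oxygen on a saturated carbon, 4-methoxyphenyl in place of 2-methylphenyl gives the first single-place step in this assay: a number 15.1 percentage points lower from compound 1 to compound 3 (beyond the scatter). This position therefore responds to a change in the group it carries, and here the response is downward. One six-membered aromatic ring of carbon only stays in place while the entering group adds one oxygen and one hydrogen-bond acceptor, so a change on that ring alone is enough to move the read-out beyond the scatter, but no measurement at hand gives a reason for the drop.

The compounds shown leave open whether the drop follows the arrival of the methoxy group or the loss of the methyl group, as this single step changes both at once. Also open, as far as these compounds go, is how the read-out would respond to a nitrile or an amine on the same ring, or to a longer chain in place of the methoxy group, which would show whether any group other than methyl holds or raises the read-out here.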